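The source may report more compounds than this note shows. Statements on the series, on what has been measured and on what is new or still open speak of the compounds shown alone.

Compound 1 `O=c1c2ccccc2[se]n1-c1nc(SCc2ccccc2)n[nH]1` carries a benzyl group on the sulfur of the shared core. In a functional assay on A549 cells (Homo sapiens) for antiproliferative activity, read by CCK-8 assay, with a stated time of 48 h (on this read-out lower numbers stand for stronger inhibition and higher numbers for weaker inhibition), compound 1 reaches only the limit of the assay, > 50000 nM, which is a limit and not a measured number. Compound 2 `CCSc1n[nH]c(-n2[se]c3ccccc3c2=O)n1` gives 39600 nM in this assay, and compound 3 `Cc1ccccc1CSc1n[nH]c(-n2[se]c3ccccc3c2=O)n1` gives 9720 nM. The step of an at least 1.2-fold lower number from compound 1 to compound 2 (0.10 log units; that floor lies within the scatter) thus stays within the scatter, while an at least 5.1-fold lower number from compound 1 to compound 3 (0.71 log units; beyond the scatter) and a 4.1-fold lower number from compound 2 to compound 3 (0.61 log units; beyond the scatter) are both modest changes beyond it.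

Compound 4 `O=c1c2ccccc2[se]n1-c1nc(SCc2ccc([N+](=O)[O-])cc2)n[nH]1` differs from compound 1 in one place: nitro in place of hydrogen on an aromatic carbon. The closest measured comparison is the step from compound 1 to compound 3, where a substituent placed on the same six-membered ring lowered the number by an at least 5.1-fold lower number from compound 1 to compound 3 (0.71 log units; beyond the scatter). A nitro group is not a methyl, so the direction is only suggested, not established. Compound 4 is therefore expected to show a step of an at least 2.5-fold lower number from compound 1 to compound 4 (0.39 log units; beyond the scatter) in this assay, toward a lower number. The estimated value for compound 4 is 20000 nM, within a range of 5000 nM to 60000 nM.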

Compound 4, half-maximal inhibitory concentration: 9140 nM
Estimate against measurement, compound 4: 2.2-fold (0.34 log units) above, within the range that was stated.
By their numbers in this assay, from the lowest: compounds 4 and 3 (each within the scatter of the next); then compound 2. At a limit, above all of these: compound 1.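

In this assay, nitro in place of hydrogen, para to a large group on the six-membered aromatic ring, gives an at least 5.4-fold lower number from compound 1 to compound 4 (0.73 log units; beyond the scatter). Until now, methyl was the only group shown to lower the number from this ring, so compound 4 shows that a second, quite different group, one with oxygen and nitrogen atoms, can do so as well. The true size of this step stays unknown, because compound 1 stands at a limit: the limit of > 50000 nM in this assay, at which 1 of the 4 values shown sits.

On these data alone, it remains open whether an amine or a carboxylic acid at this same place would lower the number as nitro does. Also open, as far as these compounds go, is how much of the change belongs to the group itself and how much to its place on the ring, a question that a methyl at this place would help to settle.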